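This account rests on a few compounds, and the source may have more. Where it says the series, first, only, none or still open, it means among the compounds named here.

Working notes on the series in a functional assay on K562 cells (Homo sapiens) for cytotoxicity, read by trypan blue exclusion, with a stated time of 96 h; a lower number here means a stronger inhibitor, a higher number a weaker inhibitor. Compound 1 `COc1cc(OC)c(/C=C/S(=O)(=O)Nc2ccc(OC)c([N+](=O)[O-])c2)c(OC)c1` gives 1000 nM, and compound 2 `COc1cc(OC)c(/C=C/S(=O)(=O)Nc2ccc(OC)c(N)c2)c(OC)c1` gives 3 nM. Compound 3 `COc1ccc(NS(=O)(=O)/C=C/c2c(OC)cc(OCCCC(=O)O)cc2OC)cc1[N+](=O)[O-]` gives 100000 nM, the highest of the three numbers. Placing 2-carboxyethyl in place of hydrogen on a saturated chain carbon bound to an oxygen on an aromatic ring corresponds to a 100-fold higher number from compound 1 to compound 3 (2.00 log units; beyond the scatter).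

Compound 4 `COc1ccc(NS(=O)(=O)/C=C/c2c(OC)cc(OCCCC(=O)O)cc2OC)cc1N` is still unmeasured. It carries amino in place of nitro on an aromatic carbon, ortho to a methoxy group, relative to compound 3: amino in place of nitro on an aromatic carbon. Within the data shown here, the same exchange has been measured in only one pair, which gave a 330-fold lower number from compound 1 to compound 2 (2.52 log units; beyond the scatter). Among the measured compounds shown here, whether a step of that size survives in the presence of the 2-carboxyethyl group is untested, since the data hold no second pair. A large step towards a lower number in this assay is therefore expected, with wide uncertainty. The expected step is a 250-fold lower number from compound 3 to compound 4 (2.40 log units; beyond the scatter). For compound 4 the estimate is 400 nM, with an expected range of 30 nM to 10000 nM.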

Compound 4, half-maximal inhibitory concentration: 10000 nM
Compound 4: middle estimate off by 25-fold (1.40 log units), on the low side; low and high end bracket the measured number.
By their numbers in this assay, from the lowest: compound 2; then compound 1; then compound 4; then compound 3.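

The exchange of nitro for amino, ortho to a methoxy group, has no fixed size in this series. With the 2-carboxyethyl group present it gives a 10-fold lower number from compound 3 to compound 4 (1.00 log units; beyond the scatter), so the size of the step depends on the core: the same change on two cores in this assay, a 330-fold lower number (2.52 log units; beyond the scatter) from compound 1 to compound 2 and a 10-fold lower number (1.00 log units; beyond the scatter) from compound 3 to compound 4, 33-fold (1.52 log units) apart, beyond the scatter of two such steps. Read the other way, the 2-carboxyethyl group gives a 3300-fold higher number from compound 2 to compound 4 (3.52 log units; beyond the scatter), a larger step between the amino compounds than between the nitro compounds, so the two changes do not add independently: the same change on two cores in this assay, a 100-fold higher number (2.00 log units; beyond the scatter) from compound 1 to compound 3 and a 3300-fold higher number (3.52 log units; beyond the scatter) from compound 2 to compound 4, 33-fold (1.52 log units) apart, beyond the scatter of two such steps.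

Open, on these data alone, is whether this dependence follows the carboxylic acid itself or the chain that carries it; a methyl ester, a primary amide or a plain butoxy chain in its place would separate the two. Also open, as far as these compounds go, is whether a hydroxyl or acetamido group in place of the amino group behaves like amino on either core.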